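The source may report more compounds than this note shows. Statements on the series, on what has been measured and on what is new or still open speak of the compounds shown alone.

Compound 1 `COc1cccc(/C=C/C(=O)c2ccc(OC)c3c2OC(C)(C)C=C3)c1` carries a 3-methoxyphenyl on a double-bonded chain carbon of the shared core. In a functional assay on SW-620 cells (Homo sapiens) for antiproliferative activity, read by MTT assay, with a stated time of 24 h (a higher number here means a weaker inhibitor, a lower number a stronger inhibitor), compound 1 gives > 10000 nM, which is a limit of the assay rather than a number. Compound 2 `COc1ccc(C(=O)/C=C/c2ccc(N(c3ccccc3)c3ccccc3)cc2)c2c1C=CC(C)(C)O2` also returns only a limit in this assay, > 10000 nM. Within the data shown here, compound 3 `COc1ccc(C(=O)/C=C/c2cccc([N+](=O)[O-])c2)c2c1C=CC(C)(C)O2` is the one compound with a number in this assay, 4090 nM. Among the measured compounds shown here, the single measured step is an at least 2.4-fold lower number from compound 1 to compound 3 (0.38 log units; beyond the scatter); its size is bounded by the limit of > 10000 nM in this assay, at which 2 of the 3 values shown sit, so the true step may be larger than stated. Compound 4 `COc1ccc(C(=O)/C=C/c2cccs2)c2c1C=CC(C)(C)O2` differs from compound 1 by thiophen-2-yl in place of 3-methoxyphenyl on a double-bonded chain carbon bound to a double-bonded chain carbon. For the measured compounds named here, no measured step exchanges the six-membered aromatic ring itself; the step from compound 1 to compound 3 alters only a substituent on that ring, so it bears on compound 4 indirectly, showing that at least modest gains from compound 1 are possible without saying anything about the ring exchange. With two of three values at the limit, the expected step in this assay from compound 1 to compound 4 is small and uncertain: an at least 1.2-fold lower number from compound 1 to compound 4 (0.09 log units; that floor lies within the scatter). Compound 4 is therefore estimated at 8000 nM, between 3000 nM and 30000 nM, with a fair chance that only a limit is returned.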

Compound 4, half-maximal inhibitory concentration: > 10000 nM
Compound 4: only a limit was reported; the forecaster's own chance of this, stated with the estimate: 55%; middle value at least 1.2-fold (0.09 log units) away from the limit.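

In this assay compound 4 gives > 10000 nM, which is a limit of the assay and not a number. Among these compounds, exchanging the 3-nitrophenyl for thiophen-2-yl on a double-bonded chain carbon gives an at least 2.4-fold higher number from compound 3 to compound 4 (0.38 log units; beyond the scatter), so a five-membered aromatic ring with 1 hetero atom at this position does not keep the measurable value of compound 3, and this is the first reading of a whole-ring exchange. The step from compound 1 to compound 4 cannot be read, and whether thiophen-2-yl differs at all from 3-methoxyphenyl stays unresolved, because both values are limits: the limit of > 10000 nM in this assay, at which 3 of the 4 values shown sit.

Among the compounds shown here, compound 3 remains the only compound with a number, so it is open whether that number belongs to the nitro group or to the six-membered aromatic ring that carries it. Also open, from the compounds shown here alone, is whether a thiophen-2-yl bearing a nitro group, or a phenyl ring bearing an amine or a carboxylic acid in place of the nitro group, would move the value clear of the limit.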